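This account rests on a few compounds, and the source may have more. Where it says the series, first, only, none or still open, it means among the compounds named here.

Measured in a physicochemical assay for solubility, read by HPLC, measured as kinetic solubility, with a stated time of 24 h, at pH 6.5; a higher number here means a more soluble compound, a lower number a less soluble compound:
Compound 1 `CC(C)(C)NCc1cc(Cl)cc(Nc2nc3ccccc3n2Cc2ccc(C(F)(F)F)cc2)c1O`: < 5000 nM
Compound 2 `CCNCc1cc(Cl)cc(Nc2nc3ccccc3n2Cc2ccc(C(F)(F)F)cc2)c1O`: 12000 nM

Going by the values given here, compound 2 holds the only number in this assay so far, 12000 nM. Compound 1, at < 5000 nM, is reported as a limit. Compound 3 `CCNCc1cc(Cl)cc(Nc2nc3ccccc3[nH]2)c1O` has hydrogen in place of 4-(trifluoromethyl)benzyl on an aromatic nitrogen. Among the compounds with values here, the only measured step is an at least 2.4-fold higher number from compound 1 to compound 2 (0.38 log units; beyond the scatter), made at an amine nitrogen, so it bears on this change only loosely. With that step as a weak guide, a larger rise in this assay is expected, given the size of the group leaving. The expected step is a 4.2-fold higher number from compound 2 to compound 3 (0.62 log units; beyond the scatter). For compound 3 the estimate is 50000 nM, with an expected range from 14000 nM to 180000 nM.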

Compound 3, solubility: 200000 nM
The estimate for compound 3 lay 4.0-fold (0.60 log units) below the measured number, and the stated range ends below it.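

In this assay, going by these compounds alone, hydrogen in place of 4-(trifluoromethyl)benzyl on the aromatic nitrogen gives a 17-fold higher number from compound 2 to compound 3 (1.22 log units; beyond the scatter) and is the first step read between two actual numbers, since compound 1 stands at a limit. The values shown give no cause for this step.

From the compounds shown here alone, how much of the step belongs to the trifluoromethyl and how much to the benzyl itself stays open; an unsubstituted benzyl or a methyl on this nitrogen would divide it. Going by these compounds, whether the step holds with tert-butyl on the amine nitrogen also stays open.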